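A few compounds are considered here, and "the series" means these few. Any claim that something is new, unique, unknown or untested is made for them only; others in the source may bear on it.

Measured so far in a functional assay on HCT-116 cells (Homo sapiens) for antiproliferative activity, read by MTT assay, with a stated time of 48 h (on this read-out lower numbers stand for stronger inhibition and higher numbers for weaker inhibition), for three compounds on the shared core:
- compound 1 `COc1ccc(-c2cc3c(cn2)[nH]c(=O)n3-c2cc(OC)c(OC)c(OC)c2)cc1O` gives 340 nM
- compound 2 `CCOc1ccc(-c2cc3c(cn2)[nH]c(=O)n3-c2cc(OC)c(OC)c(OC)c2)cc1F` gives 7220 nM
- compound 3 `COc1ccc(-c2cc3c(cn2)[nH]c(=O)n3-c2cc(OC)c(OC)c(OC)c2)cc1C(=O)O` gives 3070 nM

Compound 1 holds the lowest number of the three. Both steps away from it lie beyond the scatter: a 21-fold higher number from compound 1 to compound 2 (1.33 log units; beyond the scatter) with 4-ethoxy-3-fluorophenyl in place of 3-hydroxy-4-methoxyphenyl, and a 9.0-fold higher number from compound 1 to compound 3 (0.96 log units; beyond the scatter) with carboxy in place of hydroxy. The remaining step, a 2.4-fold lower number from compound 2 to compound 3 (0.37 log units; beyond the scatter), also lies beyond the scatter.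

Next in the series is compound 4 `COc1ccc(-c2cc3c(cn2)n(C2CC2)c(=O)n3-c2cc(OC)c(OC)c(OC)c2)cc1O`, which keeps the 3-hydroxy-4-methoxyphenyl group and changes the core of compound 1: cyclopropyl in place of hydrogen on an aromatic nitrogen. This is cyclopropyl in place of hydrogen on an aromatic nitrogen of the five-membered ring.

Going by the values given here, no measured step touches that nitrogen, since all three exchange groups on an aromatic carbon. They show how far numbers can move in this series, but they give neither size nor direction for the new change. No step beyond the scatter is therefore expected, though the uncertainty is wide on both sides. The estimate rests on compound 1 with 340 nM as its anchor. The expected step is a 1.1-fold lower number from compound 1 to compound 4 (0.05 log units; within the scatter) in this assay. For compound 4 the estimated value is 300 nM, with an expected range from 60 nM to 1500 nM.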

Compound 4, half-maximal inhibitory concentration: > 20000 nM
Compound 4 was reported as a limit; the forecaster's own chance of this, stated with the estimate: 3%; middle value at least 66-fold (1.82 log units) from the limit.
By their numbers in this assay, from the lowest: compound 1; then compound 3; then compound 2. At a limit, above all of these: compound 4.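

In this assay, going by these compounds alone, cyclopropyl in place of hydrogen on an aromatic nitrogen gives an at least 58-fold higher number from compound 1 to compound 4 (1.76 log units; beyond the scatter), a larger step than any of the exchanges on an aromatic carbon among the earlier compounds. Within the data shown here, compound 4 keeps the 3-hydroxy-4-methoxyphenyl group of compound 1 and differs from it in this one place, so the step belongs to the nitrogen of the five-membered ring and shows that this position, untouched by the earlier steps, is far from indifferent to substitution. The reading for compound 4 is a limit and not a number: the limit of > 20000 nM in this assay, at which 1 of the 4 values shown sits.

With cyclopropyl as the only group shown on this nitrogen, the data cannot tell whether the hydrogen itself is required or whether cyclopropyl in particular is poorly accepted, a question that a methyl group, an ethyl group or a longer chain ending in an amine at the same nitrogen would address. Also open, as far as these compounds go, is whether the same step appears with the 4-ethoxy-3-fluorophenyl group of compound 2 or the 3-carboxy-4-methoxyphenyl group of compound 3 in place of the group kept here.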